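Replacing methoxy with cyclohexylamino on a carbonyl carbon

The source may report more compounds than this note shows. Statements on the series, on what has been measured and on what is new or still open speak of the compounds shown alone.

Compound 1 `N[C@H]1CC[C@H](Nc2c(C(=O)NCc3ccc(F)cc3)nc(Br)c3cccnc23)CC1`: 2000 nM
Compound 2 `COC(=O)c1nc(Br)c2cccnc2c1N[C@H]1CC[C@H](N)CC1`: > 20000 nM

In a functional assay on MCF7 cells (Homo sapiens) for cytotoxicity, read by MTT assay, with a stated time of 72 h (on this read-out higher numbers stand for weaker inhibition and lower numbers for stronger inhibition), compound 2 gives only a limit, > 20000 nM, and no number.

Compound 3 `N[C@H]1CC[C@H](Nc2c(C(=O)NC3CCCCC3)nc(Br)c3cccnc23)CC1` has cyclohexylamino in place of methoxy on a carbonyl carbon. Among the measured compounds shown here, one measured step bears on this change: an at least 10-fold higher number from compound 1 to compound 2 (1.00 log units; beyond the scatter), beyond the scatter, with methoxy in place of (4-fluorobenzyl)amino on a carbonyl carbon. Since compound 3 again carries a substituted amino group there, that step is expected to run in reverse. The expected step is an at least 6.6-fold lower number from compound 2 to compound 3 (0.82 log units; beyond the scatter). For compound 3 the estimated value is 3000 nM, within a range of 1000 nM to 12000 nM.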

Compound 3, half-maximal inhibitory concentration: 5200 nM
For compound 3 the middle estimate is 1.7-fold (0.24 log units) below the measured one; measured number inside the range.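

Cyclohexylamino on the carbonyl carbon also improves on methoxy, giving an at least 3.8-fold lower number from compound 2 to compound 3 (0.58 log units; beyond the scatter), so this gain is not confined to the (4-fluorobenzyl)amino group of compound 1. The group on the amide-type nitrogen matters as well: cyclohexyl in place of 4-fluorobenzyl gives a 2.6-fold higher number from compound 1 to compound 3 (0.41 log units; beyond the scatter). Compound 2 gives only a limit, so the full size of its step to compound 3 stays unknown: the limit of > 20000 nM in this assay, at which 1 of the 3 values shown sits.

On these data alone, whether the gain requires the amide hydrogen remains open, and a dimethylamino group on the carbonyl carbon would test this. As far as these compounds go, how a carboxylic acid or an unsubstituted amino group would compare there also remains open.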